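The source may report more compounds than this note shows. Statements on the series, on what has been measured and on what is new or still open speak of the compounds shown alone.

Measured in an ADME assay on L6 cells (Rattus norvegicus) for cytotoxicity, read by resazurin assay, with a stated time of 72 h; on this read-out lower numbers stand for stronger inhibition and higher numbers for weaker inhibition:
- compound 1 `CN(C)C12CC(c3ccccc3)C(CN(CCN3CCCCC3)C1)C(c1ccccc1)C2`: 2920 nM
- compound 2 `CN(C)C12CC(c3ccccc3)C(CN(CCCN3CCCCC3)C1)C(c1ccccc1)C2`: 1750 nM
- compound 3 `CCN(CC)CC(=O)N1CCC2(N(C)C)CC(c3ccccc3)C1C(c1ccccc1)C2`: 89600 nM

At 89600 nM, compound 3 has the highest number of the three in this assay, and its distance to each of the other two lies beyond the scatter. The next compound, compound 4 `CCN(CC)CCN1CCC2(N(C)C)CC(c3ccccc3)C1C(c1ccccc1)C2`, has not yet been measured. It replaces ((diethylamino)methyl)carbonyl with 2-(diethylamino)ethyl on an amine nitrogen in a ring: 2-(diethylamino)ethyl in place of ((diethylamino)methyl)carbonyl on an amine nitrogen in a ring.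

Within the data shown here, no measured step makes this change. The only one available, a 1.7-fold lower number from compound 1 to compound 2 (0.22 log units; within the scatter), lies within the scatter and concerns a different chain, so it says little here. The indirect evidence is that compound 1, at 2920 nM, and compound 2, at 1750 nM, both carry a chain without a carbonyl, although their core differs from that of compound 3. A sizeable move towards a lower number in this assay is therefore expected, beyond the scatter, though probably stopping short of those two values. The expected step is a 15-fold lower number from compound 3 to compound 4 (1.17 log units; beyond the scatter). For compound 4 the estimated value is 6000 nM, with an expected range of 1800 nM to 25000 nM.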

Compound 4, half-maximal inhibitory concentration: 101000 nM
Compound 4: the middle estimate sits 17-fold (1.23 log units) below what was measured; the whole stated range lies below it.
By their numbers in this assay, from the lowest: compounds 2 and 1 (each within the scatter of the next); then compounds 3 and 4 (each within the scatter of the next).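

In this assay, putting 2-(diethylamino)ethyl in place of ((diethylamino)methyl)carbonyl on the amine nitrogen in the seven-membered ring gives a 1.1-fold higher number from compound 3 to compound 4 (0.05 log units; within the scatter), so on this core, losing the carbonyl with its oxygen leaves the two compounds level. The carbonyl at this position therefore cannot by itself be what sets compound 3 and compound 4 apart from compound 1 and compound 2, which differ from them in more than one place and so allow no direct reading of any single change. Nothing measured here explains why this exchange leaves the read-out level.

Going by these compounds, what remains open is whether the chain on this ring nitrogen matters at all on this core: a longer chain such as 3-(diethylamino)propyl, a piperidine or morpholine at the chain end, or a simple methyl group in its place could each show whether the number can move from this position. On these data alone, it is also open whether the same exchange of carbonyl for a chain without one would stay as flat on the core of compound 1.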